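The source may hold more compounds than are shown below. What is called first, only, known or untested is meant among the compounds shown, and "the series" means these compounds.

In a toxicity assay on MDCK cells (Canis lupus familiaris) for cytotoxicity, read by crystal violet staining, with a stated time of 48 h (a lower number here means that less compound is tolerated, a higher number that more compound is tolerated), compound 1 `COc1ccc(CN(Cc2ccc(C(C)(C)C)cc2)Cc2cc3cc(C)ccc3[nH]c2=O)cc1` gives only a limit, > 10000 nM. Compound 2 `Cc1ccc2[nH]c(=O)c(CN(Cc3ccc(OC(F)F)cc3)Cc3ccc(C(C)(C)C)cc3)cc2c1` also reaches only a limit in this assay, > 5000 nM. For the measured compounds named here, the single measured step between them, a step that the two limits leave unreadable from compound 1 to compound 2, therefore has no readable size. Compound 3 `Cc1ccc2[nH]c(=O)c(CN(Cc3ccc(C(C)(C)C)cc3)C(C)c3ccc(F)cc3)cc2c1` differs from compound 2 by 1-(4-fluorophenyl)ethyl in place of 4-(difluoromethoxy)benzyl on an amine nitrogen. Going by the values given here, no measured step covers this change, and the two limits give neither a size nor a direction, so nothing beyond the scatter is expected. Compound 3 is expected near 10000 nM, between 3000 nM and 30000 nM. The expected step is a step that the limit leaves unreadable from compound 2 to compound 3, and it may again show only as a limit.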

Compound 3, half-maximal cytotoxic concentration: > 33000 nM
Compound 3: only a limit was reported; the forecaster's own chance of this, stated with the estimate: 60%; middle value at least 3.3-fold (0.51 log units) from the limit.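

For the compounds shown here, compound 1, compound 2 and compound 3 all give only limits in this assay, and no step among them can be read. The compounds shown leave open at what concentration each one harms the cells, and whether changing the group on the amine nitrogen shifts that concentration.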